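This account rests on a few compounds, and the source may have more. Where it says the series, first, only, none or still open, it means among the compounds named here.

Compound 1 `CC1CCN(C(=O)CCCNC(=O)c2ccc(S(C)(=O)=O)c([N+](=O)[O-])c2)CC1` and compound 2 `CS(=O)(=O)c1ccc(C(=O)NCCCC(=O)N2CCCCC2)cc1[N+](=O)[O-]` share the same core and differ only by hydrogen in place of methyl on a saturated ring carbon. In an assay on isolated protein for inhibition of thyroid hormone receptor alpha (Homo sapiens), read by fluorescence polarization (on this read-out lower numbers stand for stronger inhibition and higher numbers for weaker inhibition), compound 1 gives > 60000 nM, which is a limit of the assay and not a number. In this assay compound 2 gives > 60000 nM, again a limit rather than a number. That change yields a step that the two limits leave unreadable from compound 1 to compound 2, and its size cannot be read because both values sit at the limit of > 60000 nM in this assay, at which 2 of the 2 values shown sit. Compound 2 therefore stands only at a limit, with no measured number to place it.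

Compound 3 `CN(Cc1ccccc1F)C(=O)CCCNC(=O)c1ccc(S(C)(=O)=O)c([N+](=O)[O-])c1` differs from compound 2 by (2-fluorobenzyl)(methyl)amino in place of piperidin-1-yl on a carbonyl carbon, a change on a carbonyl carbon whose other neighbour is a saturated chain carbon. No measured step bears on this kind of exchange, and the single step shown is unreadable. With both measured values at the limit, compound 3 is expected to remain at the limit as well. Compound 3 is estimated at 80000 nM, with a range from 20000 nM to 300000 nM. This amounts to an expected step that the limit leaves unreadable from compound 2 to compound 3, with no readable direction.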

Compound 3, half-maximal inhibitory concentration: > 60000 nM
Compound 3 gave a limit, no number; the forecaster's own chance of this, stated with the estimate: 85%; the middle value does not contradict the limit.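

No new step can be read from compound 3, since its result in this assay is a limit, as are those of compound 1 and compound 2: the limit of > 60000 nM in this assay, at which 3 of the 3 values shown sit.

The compounds shown leave open how far these three lie from one another in this assay, and whether any change on the shared core would give a measured number.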